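This account rests on a few compounds, and the source may have more. Where it says the series, first, only, none or still open, it means among the compounds named here.

Measured in a functional assay on NALM-6 cells (Homo sapiens) for cytotoxicity, with a stated time of 72 h; on this read-out higher numbers stand for an effect only at larger amounts of compound and lower numbers for an effect already at smaller amounts
compound 1 `C=C[C@@](C)(/C=C/c1ccc(Nc2cc(F)c(F)c(F)c2)cc1)CCC=C(C)C` | > 43400 nM
compound 2 `C=C[C@@](C)(/C=C/c1ccc(Nc2ccc(Cl)cc2)cc1)CCC=C(C)C` | > 43400 nM

In this assay compound 2 gives > 43400 nM as a limit of the assay and not a number. Compound 1 gives > 43400 nM which is likewise a limit. Both measured compounds therefore share one position, namely the limit of > 43400 nM in this assay, at which 2 of the 2 values shown sit, with no number yet on either side of it.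

Going by the values given here, the only measured step is a step that the two limits leave unreadable from compound 1 to compound 2 and it offers no size to carry forward.

Compound 3 `C=C[C@@](C)(/C=C/c1ccc(Nc2ccc(Cl)c(Cl)c2)cc1)CCC=C(C)C` differs from compound 2 in one place by chloro in place of hydrogen on an aromatic carbon and the change reads as 4-chlorophenyl to 3,4-dichlorophenyl. Compound 2 at > 43400 nM offers only a limit to start from, so no step beyond the scatter can be expected in either direction in this assay and a further limit is the likeliest report.

The expected step is a number no higher from compound 2 to compound 3 (the limit leaves the size open) as an estimate set against a limit. For compound 3 the estimated value is 43000 nM with an expected range of 15000 nM to 90000 nM if a number is reported at all.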

Compound 3, half-maximal effective concentration: > 43400 nM
Compound 3 ended at the assay's limit (the forecaster's own chance of this, stated with the estimate: 80%); middle value at least 1.0-fold (0.00 log units) from the limit.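

In this assay compound 3 gives > 43400 nM, a limit of the assay and not a number. Going by these compounds alone, the steps to compound 3 from compound 1 and from compound 2 cannot be read, so no new step emerges. Left open is how the 3,4,5-trifluorophenyl, 4-chlorophenyl and 3,4-dichlorophenyl groups compare, as all three compounds share one position: the limit of > 43400 nM in this assay, at which 3 of the 3 values shown sit.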